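Swapping the Benzyl Group: From Compound 2 to Compound 3

The source may hold more compounds than are shown below. What is called first, only, known or untested is meant among the compounds shown, and "the series" means these compounds.

Of the compounds shown here, two with a shared core have been tested in a functional assay on MGC-803 cells (Homo sapiens) for inhibition, read by MTT assay, with a stated time of 48 h; on this read-out lower numbers stand for stronger inhibition and higher numbers for weaker inhibition. In this assay compound 1 `Cc1ccc(NC(=S)NC(=O)c2ccc(OCc3ccc(Cl)c(Cl)c3)cc2)cc1-c1nc2ccccc2[nH]1` gives 6390 nM. In this assay compound 2 `Cc1ccc(NC(=O)NC(=O)c2ccc(OCc3cccc(C(F)(F)F)c3)cc2)cc1-c1nc2ccccc2[nH]1` gives 13100 nM, the higher of the two numbers, and its gap to compound 1 lies beyond the usual scatter. Compound 3 `Cc1ccc(NC(=O)NC(=O)c2ccc(OCc3ccccc3Cl)cc2)cc1-c1nc2ccccc2[nH]1` has not yet been measured; it differs from compound 2 in one place: 2-chlorophenyl in place of 3-(trifluoromethyl)phenyl on a saturated chain carbon bound to an oxygen on an aromatic ring. Among the compounds with values here, no measured pair shows this kind of change, so only a small step is expected, a 1.3-fold lower number from compound 2 to compound 3 (0.12 log units; within the scatter), likely within the scatter. For compound 3 the estimate in this assay is 10000 nM, between 4000 nM and 30000 nM.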

Compound 3, half-maximal inhibitory concentration: 19500 nM
Beside the measured number, compound 3's estimate is 2.0-fold (0.29 log units) below it; measured number inside the range.
By their numbers in this assay, from the lowest: compound 1; then compounds 2 and 3 (each within the scatter of the next).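

At this position, on a saturated chain carbon bound to an oxygen on an aromatic ring, 2-chlorophenyl in place of 3-(trifluoromethyl)phenyl gives a small step in this assay (a 1.5-fold higher number from compound 2 to compound 3 (0.17 log units; within the scatter)). This first single-place comparison shows that these two substituted phenyl groups cannot be told apart here, even though they differ in the group on the ring and in heavy-atom count. No measurement available here accounts for this result.

Compound 1 differs from compound 2 and compound 3 in more than one place, so its lower number cannot be assigned to one change. Going by these compounds, what an amine or a carboxylic acid on this ring would do remains open.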